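This account rests on a few compounds, and the source may have more. Where it says the series, first, only, none or still open, it means among the compounds named here.

Three thiourea analogues sharing one core have been compared in a functional assay on MDA-MB-231 cells (Homo sapiens) for antiproliferative activity, read by MTT assay; on this read-out higher numbers stand for weaker inhibition and lower numbers for stronger inhibition. Compound 1, `CNC(=O)c1ccc(Oc2cccc(NC(=S)Nc3ccc(OC(F)(F)F)cc3)c2)nc1`, gives 56000 nM. Compound 2, `CNC(=O)c1ccc(Oc2cccc(NC(=S)Nc3cc(C(F)(F)F)cc(C(F)(F)F)c3)c2)nc1`, gives 2670 nM. Compound 3, `CNC(=O)c1ccc(Oc2cccc(NC(=S)Nc3ccc(F)c(C(F)(F)F)c3)c2)nc1`, gives 13300 nM, the second highest number of the three: compound 1 sits above it and compound 2 below it, both gaps beyond the usual scatter. The next analogue, compound 4, `CNC(=O)c1ccc(Oc2cccc(NC(=S)Nc3ccc(F)c(F)c3)c2)nc1`, differs from compound 3 in one place: fluoro in place of trifluoromethyl on an aromatic carbon. For the measured compounds named here, no measured pair shows this exact change. Compound 3 is expected to move to a higher number in compound 4, a step of a 2.3-fold higher number from compound 3 to compound 4 (0.35 log units; beyond the scatter) in this assay. Compound 4 is therefore estimated at 30000 nM, with a range from 10000 nM to 90000 nM.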

Compound 4, half-maximal inhibitory concentration: 69300 nM
Estimate against measurement, compound 4: 2.3-fold (0.36 log units) below; the measured number falls inside the stated range.
By their numbers in this assay, from the lowest: compound 2; then compound 3; then compounds 1 and 4 (each within the scatter of the next).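

In this assay, fluoro in place of trifluoromethyl, on an aromatic carbon ortho to a fluoro group and meta to a large group, brings a 5.2-fold higher number from compound 3 to compound 4 (0.72 log units; beyond the scatter) and gives the series its first step that changes one place only. This position is therefore not indifferent to its substituent: with the other fluoro group unchanged, the change from four heavy atoms to one weakens inhibition. No evidence at hand explains this step. Going by these compounds, whether a methyl group, a methoxy group or an amine would keep the inhibition of trifluoromethyl here remains open, as does whether hydrogen would weaken it further.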